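The compounds below may be only part of what the source reports. "The series", "measured", "known", "first", "only" and "open" are said of these compounds alone.

The data here come from a functional assay on the whole organism (blood, strain Wistar-Okamoto) with Rattus norvegicus as the target, with a stated time of 5 days; a higher number here means that more compound is needed for the effect, a lower number that less compound is needed. Compound 1 `CCCC(C)(C)/N=C(\NC#N)Nc1cccnc1` gives 1 mg/kg. Compound 2 `CC(C)CC(C)(C)/N=C(\NC#N)Nc1cccnc1` carries one carbon more on its chain: methyl in place of hydrogen on a saturated chain carbon bound to two saturated chain carbons. In this assay compound 2 gives 2.5 mg/kg, and the step of a 2.5-fold higher number from compound 1 to compound 2 (0.40 log units; beyond the scatter) shows that this small addition made more compound necessary for the effect. Compound 3 `CCC(C)(CC)/N=C(\NC#N)Nc1ccncc1` has the same atoms as compound 1, joined differently; the difference between the two cores is not broken down here. In this assay compound 3 gives 0.5 mg/kg; its gap to compound 1 lies within the scatter of repeated measurements, while its gap to compound 2 lies beyond it.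

Compound 4 `CCC(CC)(CC)/N=C(\NC#N)Nc1ccncc1` has not yet been measured. It differs from compound 3 by methyl in place of hydrogen on a saturated chain carbon, two bonds along the chain from a double-bonded nitrogen. For the measured compounds named here, this is the same kind of change as the one between compound 1 and compound 2, but not the same: there the new methyl sat on a saturated chain carbon bound to two saturated chain carbons, here it sits on a saturated chain carbon two bonds along the chain from a double-bonded nitrogen. Going by the values given here, the expected step is a 2.0-fold higher number from compound 3 to compound 4 (0.30 log units; within the scatter), because a 2.5-fold higher number from compound 1 to compound 2 (0.40 log units; beyond the scatter) is the only measured step of this kind and it made the number larger. This expectation rests on that single pair and on compound 3 giving 0.5 mg/kg. Compound 4 is therefore estimated to need 1 mg/kg, with a likely range from 0.4 mg/kg to 3 mg/kg.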

Compound 4, minimum effective dose: 2.5 mg/kg
For compound 4 the middle estimate is 2.5-fold (0.40 log units) below the measured one; low and high end bracket the measured number.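

In this assay the added methyl again raises the number, with a 5.0-fold higher number from compound 3 to compound 4 (0.70 log units; beyond the scatter), so on this second core too more compound is needed for the effect. Set side by side, the two steps point the same way and their sizes cannot be told apart: the same change on two cores in this assay, a 2.5-fold higher number (0.40 log units; beyond the scatter) from compound 1 to compound 2 and a 5.0-fold higher number (0.70 log units; beyond the scatter) from compound 3 to compound 4, 2.0-fold (0.30 log units) apart, within the scatter of two such steps. In these two pairs, then, the change carried over from one core to the other, even though the new methyl does not sit at the same place on the chain in each pair; this does not show why the number rises, and two pairs are too few to say that the same would happen on any further core in this series.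

What the compounds shown leave open is whether the number keeps rising as the chain grows further, for example with a longer chain in place of one of the ethyl groups, and whether the step would keep its size if the methyl sat at the same chain place on both cores. They also leave open what a different kind of group on the chain, such as an amine or a carboxylic acid, would do to the dose needed.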